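Swapping the aryl arm on a shared core

This account rests on a few compounds, and the source may have more. Where it says the series, first, only, none or still open, it means among the compounds named here.

Of the compounds shown here, three built on one shared core have been tested in a functional assay on BJAB cells (Homo sapiens) for antiproliferative activity, with a stated time of 4 days; on this read-out higher numbers stand for an effect only at larger amounts of compound and lower numbers for an effect already at smaller amounts. Compound 1, `Cc1nn(-c2nc(-c3ccc(Cl)c(Cl)c3)c(SC(C)C)s2)c(C(=O)O)c1-c1cncnc1`, gives 22000 nM. Compound 2, `COc1cc(-c2c(C)nn(-c3nc(-c4ccc(Cl)c(Cl)c4)c(SC(C)C)s3)c2C(=O)O)cc(C(F)(F)F)c1`, gives 1380 nM, and compound 3, `COc1cc(C#N)cc(-c2c(C)nn(-c3nc(-c4ccc(Cl)c(Cl)c4)c(SC(C)C)s3)c2C(=O)O)c1`, gives 5200 nM. Compound 3 therefore holds the second highest of the three numbers: there is a 3.8-fold higher number from compound 2 to compound 3 (0.58 log units; beyond the scatter), while there is a 4.2-fold lower number from compound 1 to compound 3 (0.63 log units; beyond the scatter).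

Compound 4, `Cc1nn(-c2nc(-c3ccc(Cl)c(Cl)c3)c(SC(C)C)s2)c(C(=O)O)c1-c1ccccc1Cl`, differs from compound 3 in a single place: 2-chlorophenyl in place of 3-cyano-5-methoxyphenyl on an aromatic carbon. Within the data shown here, every measured step so far changed the group at this same position, so all three bear on the change. The steps of a 16-fold lower number from compound 1 to compound 2 (1.20 log units; beyond the scatter) and a 4.2-fold lower number from compound 1 to compound 3 (0.63 log units; beyond the scatter) show that exchanging pyrimidin-5-yl for a substituted phenyl lowered the number, modestly in one case and by a large amount in the other, and a 3.8-fold higher number from compound 2 to compound 3 (0.58 log units; beyond the scatter) shows that the substituents on that phenyl shift the number by a modest amount. Among the measured compounds shown here, a phenyl bearing a single chlorine has no direct precedent here, so a number in the range spanned by compound 2 and compound 3 is expected, with a modest drop from compound 3 the most likely outcome. The expected step is a 1.7-fold lower number from compound 3 to compound 4 (0.24 log units; within the scatter). Compound 4 is thus estimated at 3000 nM, within 800 nM to 12000 nM.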

Compound 4, half-maximal effective concentration: 13100 nM
Beside the measured number, compound 4's estimate is 4.4-fold (0.64 log units) below it; the measured number lies above the stated range.
By their numbers in this assay, from the lowest: compound 2; then compound 3; then compounds 4 and 1 (each within the scatter of the next).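

In this assay, a phenyl at this position does not by itself lower the number: with a 1.7-fold lower number from compound 1 to compound 4 (0.23 log units; within the scatter), 2-chlorophenyl and pyrimidin-5-yl cannot be told apart, so the drop seen earlier on leaving pyrimidin-5-yl does not extend to every phenyl. The two phenyl groups carrying a methoxy and a second substituent both give lower numbers than 2-chlorophenyl, with a 2.5-fold higher number from compound 3 to compound 4 (0.40 log units; beyond the scatter) and a 9.5-fold higher number from compound 2 to compound 4 (0.98 log units; beyond the scatter), so among these compounds the substituents on the phenyl matter at least as much as the phenyl ring itself. No measurement shown here accounts for these differences.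

Replacing either of those two arms with 2-chlorophenyl removes the methoxy and its partner group and also introduces a chlorine at a different place on the ring, so these compounds cannot show which of those changes drives the steps. A plain phenyl with no substituent, or a phenyl bearing only a methoxy or only an amine, would be needed to separate the contribution of each substituent at this position on the shared core.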